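This account rests on a few compounds, and the source may have more. Where it says the series, first, only, none or still open, it means among the compounds named here.

Compound 1, `COc1ccc(-c2cc3c(OC)cc(OC)cc3n(C)c2=O)cc1` — 10000 nM
Compound 2, `CCOC(=O)Cn1c(=O)c(-c2ccc(OC)cc2)cc2c(OC)cc(OC)cc21` — 10000 nM
Compound 3, `COc1ccc(-c2cc3c(OC)cc(OC)cc3n(CCCC#N)c2=O)cc1` — 10000 nM

Of the compounds shown here, three have been measured in a functional assay on LoVo cells (Homo sapiens) for cytotoxicity, read by colorimetric assay and MTT assay; a lower number here means a stronger inhibitor, a higher number a weaker inhibitor. Compound 1 stands level with compounds 2 and 3 at the digits shown: the step of no change at the digits printed from compound 1 to compound 2 (within the scatter) and the step of no change at the digits printed from compound 1 to compound 3 (within the scatter) both lie within the scatter, as does the step of no change at the digits printed from compound 2 to compound 3 (within the scatter). All three measured steps alter only the group on the saturated chain carbon bound to the aromatic nitrogen, and none of them moves the read-out.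

Compound 4, `COc1cc(OC)c2cc(-c3ccc(O)cc3)c(=O)n(C)c2c1`, differs from compound 1 at a different place: hydrogen in place of methyl on an oxygen on an aromatic ring. Among the measured compounds shown here, no measured step touches this oxygen, so none of the three steps bears directly on the change; the only guidance is that every change tried so far on this core has left the read-out where it was. On that basis, compound 4 is expected to show no step beyond the scatter, the expected step being no change at the digits printed from compound 1 to compound 4 (within the scatter). Compound 4 is therefore estimated at 10000 nM, with a range from 4000 nM to 25000 nM.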

Compound 4, half-maximal inhibitory concentration: 10000 nM
Compound 4: the middle estimate sits on the measured number at the digits printed, and the stated range covers the measured number.
By their numbers in this assay, from the lowest: compounds 1, 2, 3 and 4 (each within the scatter of the next).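

In this assay, replacing methyl with hydrogen on an oxygen on an aromatic ring, which turns methoxy into hydroxy, gives no change at the digits printed from compound 1 to compound 4 (within the scatter) and so extends the picture beyond the saturated chain carbon bound to the aromatic nitrogen. The 4-methoxyphenyl group of compound 1 can thus become the 4-hydroxyphenyl group of compound 4 without a step beyond the scatter, the same outcome as the three changes at the chain carbon. No measurement shown offers an explanation for this result.

On these data alone, it remains open whether a longer chain, an amine or a carboxylic acid on this oxygen would move the read-out, and the same question stands for the other methoxy groups on the shared core. The four compounds shown include no change that separates any compound from the others in this assay.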